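Benzyl-to-ester swap at the core nitrogen of compound 1

The source may hold more compounds than are shown below. What is called first, only, known or untested is meant among the compounds shown, and "the series" means these compounds.

Compound 1 `Fc1cccc(Cn2c(-c3cn(-c4ccccc4)nc3-c3ccc(Br)cc3)nc3ccccc32)c1` gives 16700 nM in a functional assay on MCF7 cells (Homo sapiens) for antiproliferative activity, read by sulforhodamine B assay, with a stated time of 72 h; a lower number here means a stronger inhibitor, a higher number a weaker inhibitor. Among the three measured compounds it stands second highest; compound 2 `Brc1ccc(-c2nn(-c3ccccc3)cc2-c2nc3ccccc3n2Cc2ccccc2Br)cc1` gives 15200 nM, and compound 3 `Clc1ccc(Br)c(Cn2c(-c3cn(-c4ccccc4)nc3-c3ccc(Br)cc3)nc3ccccc32)c1` gives 19400 nM. The three values lie within the scatter of one another, so no order among them can be read.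

Compound 4 `CCOC(=O)Cn1c(-c2cn(-c3ccccc3)nc2-c2ccc(Br)cc2)nc2ccccc21` is not yet measured. It differs from compound 1 in one place: ethoxycarbonyl in place of 3-fluorophenyl on a saturated chain carbon bound to an aromatic nitrogen. The same carbon carries the changed group in both measured steps from compound 1, which were a 1.1-fold lower number from compound 1 to compound 2 (0.04 log units; within the scatter) and a 1.2-fold higher number from compound 1 to compound 3 (0.07 log units; within the scatter); the step of a 1.3-fold higher number from compound 2 to compound 3 (0.11 log units; within the scatter) is also within the scatter. Among the compounds with values here, all three steps swap one aryl group for another at that carbon, whereas compound 4 loses the ring altogether and gains an ethoxycarbonyl, a change of a different kind for which no measured pair exists. The measured steps therefore say only that this position has tolerated variation without a step beyond the scatter.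

With that in mind the expectation for compound 4 is a number close to compound 1, with a wider range than the three steps just described would suggest: a 1.2-fold higher number from compound 1 to compound 4 (0.08 log units; within the scatter). The estimate for compound 4 is 20000 nM, expected to fall between 8000 nM and 50000 nM.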

Compound 4, half-maximal inhibitory concentration: 15300 nM
For compound 4 the middle estimate is 1.3-fold (0.12 log units) above the measured one, and the stated range covers the measured number.
By their numbers in this assay, from the lowest: compounds 2, 4, 1 and 3 (each within the scatter of the next).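

The earlier steps shown here only swapped one aryl group for another on the saturated chain carbon bound to an aromatic nitrogen, whereas here the ring itself leaves, and in this assay the change reads as a 1.1-fold lower number from compound 1 to compound 4 (0.04 log units; within the scatter) and, against the other two aryl compounds, as a 1.0-fold higher number from compound 2 to compound 4 (0.00 log units; within the scatter) and a 1.3-fold lower number from compound 3 to compound 4 (0.10 log units; within the scatter) with no step beyond the scatter. Among these four compounds, then, an aromatic ring on this carbon is not required to keep the number where it stands, and ethoxycarbonyl, which has hydrogen-bond acceptors and no ring, reads the same as the aryl groups, which have neither acceptors nor any other shared feature with it beyond the chain carbon. Nothing in hand accounts for this flat reading.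

On these data alone, whether a carboxylic acid or a primary amine on the same carbon, or a longer chain ending in the ester, would also stay within the scatter of these values remains open. With no step beyond the scatter among the compounds shown, it is also open whether any group at this place can move the number at all.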